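The source may hold more compounds than are shown below. What is called first, only, known or untested is meant among the compounds shown, and "the series" means these compounds.

The measured compounds are:
Compound 1, `O=C(NCCCc1ccccc1)c1ccc([N+](=O)[O-])o1`, with 11000 nM in an ADME assay on Vero cells (Chlorocebus sabaeus) for cytotoxicity, read by MTT assay, with a stated time of 48 h; a higher number here means that more compound is tolerated, a lower number that less compound is tolerated.
Compound 2, `CC(NC(=O)c1ccc([N+](=O)[O-])o1)c1ccccc1`, with 24000 nM in this assay.
Compound 3, `CC(C)(NC(=O)c1ccc([N+](=O)[O-])o1)c1ccccc1`, with > 180000 nM in this assay; this result is a limit, not a number.

Compound 3 stands highest among the three results, though only as a limit: its result is the limit of > 180000 nM in this assay, at which 1 of the 3 values shown sits, so only a lower bound is known for it. For the measured compounds named here, the one step among the measured compounds, an at least 7.5-fold higher number from compound 2 to compound 3 (0.87 log units; beyond the scatter), runs up to that limit. Compound 4, `CC(C)(NC(=O)c1ccc([N+](=O)[O-])o1)c1ccc(Cl)cc1`, differs from compound 3 by chloro in place of hydrogen on an aromatic carbon. Going by the values given here, no measured step covers a change of this kind; the step from compound 2 to compound 3 concerns a methyl on the saturated chain carbon and does not speak to a chloro on the aromatic ring, so no direction can be read from it. Compound 3 sits at the limit (the limit of > 180000 nM in this assay, at which 1 of the 3 values shown sits). Compound 4 is therefore expected to give a result in this assay within the scatter of compound 3, with a step that the limit leaves unreadable from compound 3 to compound 4 as the expected step, meaning none beyond the scatter. Compound 4 is estimated at 200000 nM, with a range from 60000 nM to 500000 nM, and the outcome is expected most likely to be again a limit rather than a number.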

Compound 4, half-maximal cytotoxic concentration: 81000 nM
The estimate for compound 4 lay 2.5-fold (0.39 log units) above the measured number, and the stated range covers the measured number.
By their numbers in this assay, from the lowest: compound 1; then compound 2; then compound 4. At a limit, above all of these: compound 3.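

For the compounds shown here, the first reading on the aromatic ring comes from chloro in place of hydrogen on an aromatic carbon, para to a large group, which gives an at least 2.2-fold lower number from compound 3 to compound 4 (0.34 log units; beyond the scatter) in this assay. Going by these compounds alone, this place on the ring therefore bears on the result in this assay, and the change runs in the opposite direction to the one step known before, at the saturated chain carbon, which was an at least 7.5-fold higher number from compound 2 to compound 3 (0.87 log units; beyond the scatter). As far as these compounds go, the true size of the chloro step stays unknown, and only its lower bound can be given, because compound 3 stands at a limit: the limit of > 180000 nM in this assay, at which 1 of the 4 values shown sits.

From the compounds shown here alone, whether this lower number belongs to chloro in particular remains open, since a single substituent at a single place cannot separate it from what fluoro, methoxy or trifluoromethyl would do there, or from what chloro would do elsewhere on the ring. Also open, going by these compounds, is whether the same chloro would shift the result in the same direction on compound 2 or compound 1, which lack one or both of the methyl groups on the chain carbon of compound 3.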